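A few compounds are considered here, and "the series" means these few. Any claim that something is new, unique, unknown or untested is made for them only; others in the source may bear on it.

Measured in a functional assay on HCT-116 cells (Homo sapiens) for cytotoxicity, read by MTT assay, with a stated time of 48 h; on this read-out lower numbers stand for stronger inhibition and higher numbers for weaker inhibition:
- Compound 1 `COc1ccc(-c2c3ccc4ccccc4c3nc3c2c(C)nc2c4ccccc4ccc32)cc1`: > 80000 nM (a limit, not a number)
- Compound 2 `Cc1nc2c3ccccc3ccc2c2nc3c(ccc4ccccc43)c(-c3ccccc3S)c12`: 1420 nM

Not yet measured:
- Compound 3 `Cc1nc2c3ccccc3ccc2c2nc3c(ccc4ccccc43)c(C)c12`

Among the measured compounds shown here, compound 2 holds the only true number in this assay, at 1420 nM. Compound 1 gives only a limit of the assay, > 80000 nM.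

Compound 3 keeps the shared core but carries methyl in place of 2-sulfanylphenyl on an aromatic carbon, opposite the ring nitrogen (methyl in place of 2-sulfanylphenyl on an aromatic carbon). For the measured compounds named here, one measured step bears on this carbon: an at least 56-fold lower number from compound 1 to compound 2 (1.75 log units; beyond the scatter). That large step shows that the group here can move the number well beyond the scatter, although its true size is open at one end. Going by the values given here, no measured compound carries a group as small as methyl at this carbon, so the size of the next step is uncertain. Losing the 2-sulfanylphenyl of compound 2 is nevertheless expected to give a higher number in this assay, beyond the scatter. The expected move is a 7.0-fold higher number from compound 2 to compound 3 (0.85 log units; beyond the scatter). For compound 3 the estimated value is 10000 nM, with an expected range of 1500 nM to 70000 nM.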

Compound 3, half-maximal inhibitory concentration: > 80000 nM
Compound 3: no number, only a limit; the forecaster's own chance of this, stated with the estimate: 25%; at least 8.0-fold (0.90 log units) between middle value and limit.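

Among the compounds shown here, the earlier step at this aromatic carbon, opposite the ring nitrogen, compared only two aryl groups, so it could not show whether the 2-sulfanylphenyl group mattered or whether compound 1 was the exception. In this assay, replacing that group with methyl gives an at least 56-fold higher number from compound 2 to compound 3 (1.75 log units; beyond the scatter), a large step whose true size is open at one end, so among these three compounds only the one with 2-sulfanylphenyl gives a true number, while 4-methoxyphenyl, which also brings a six-membered aromatic ring, and methyl, which brings no ring, both end at a limit. The steps between compound 1 and compound 3 cannot be read, and the two cannot be ordered: the limit of > 80000 nM in this assay, at which 2 of the 3 values shown sit.

The compounds shown leave open whether the number of compound 2 depends on the sulfur, on the aromatic ring that carries it, or on the two together, since neither an unsubstituted phenyl nor a 2-hydroxyphenyl or 2-aminophenyl group appears at this carbon. They also leave open whether a small sulfur group without the ring, such as a sulfanylmethyl chain, would give a true number in this assay.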